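The source may hold more compounds than are shown below. What is called first, only, known or untested is meant among the compounds shown, and "the series" means these compounds.

Three compounds share one core and differ only in the group on a saturated chain carbon bound to an oxygen on a saturated carbon. In a functional assay on HEK293 cells for agonist activity at G-protein coupled receptor 39 (Homo sapiens), read by scintillation proximity assay and inositol phosphate accumulation, with a stated time of 75 min, in the presence of a further agent that is not named here (a lower number here means that less compound is needed, a higher number that more compound is needed for the effect), compound 1 `Cc1nn(-c2ncnc3nc[nH]c23)c2c1C(OCc1cc(F)cc3c1OCOC3)CC(=O)N2` gives 1.5 nM. Compound 2 `Cc1nn(-c2ncnc3nc[nH]c23)c2c1C(OCc1ccc(Cl)cc1Cl)CC(=O)N2` gives 4 nM, and compound 3 `Cc1nn(-c2ncnc3nc[nH]c23)c2c1C(OCc1ccccc1F)CC(=O)N2` gives 4 nM. Compound 3 therefore stands level with compound 2 at the digits shown, the two together giving the highest numbers of the three, while compound 1 lies furthest off: a 2.7-fold higher number from compound 1 to compound 3 (0.43 log units; beyond the scatter). All measured steps are small: a 2.7-fold higher number from compound 1 to compound 2 (0.43 log units; beyond the scatter) is modest, and no change at the digits printed from compound 2 to compound 3 (within the scatter).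

Compound 4 `COc1ccc(CCOC2CC(=O)Nc3c2c(C)nn3-c2ncnc3nc[nH]c23)cc1` departs from compound 3 by 4-methoxybenzyl in place of 2-fluorophenyl on a saturated chain carbon bound to an oxygen on a saturated carbon. Read one bond further out, the change is 2-fluorobenzyl to 2-(4-methoxyphenyl)ethyl. For the measured compounds named here, no measured step covers this exchange directly; the steps from compound 1 to compound 2 and from compound 2 to compound 3 exchange one aryl group for another and shift the number at most modestly. On that basis compound 4 is expected to land near compound 3, so that a 1.5-fold higher number from compound 3 to compound 4 (0.18 log units; within the scatter) is estimated to fall within the scatter or only a little beyond it. The expected value for compound 4 is 6 nM, with a range from 2 nM to 20 nM.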

Compound 4, half-maximal effective concentration: 2 nM
Compound 4: middle estimate off by 3.0-fold (0.48 log units), on the high side; low and high end bracket the measured number.
By their numbers in this assay, from the lowest: compounds 1, 4, 2 and 3 (each within the scatter of the next, the first and the last beyond it).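

In this assay the place on a saturated chain carbon bound to an oxygen on a saturated carbon accepts 2-(4-methoxyphenyl)ethyl as well as the benzyl groups, with steps that stay within the scatter (a 2.0-fold lower number from compound 3 to compound 4 (0.30 log units; within the scatter)) and (a 2.0-fold lower number from compound 2 to compound 4 (0.30 log units; within the scatter)). For the compounds shown here, compound 4 carries no fluorine or chlorine, yet it also lies within the scatter of compound 1 (a 1.3-fold higher number from compound 1 to compound 4 (0.12 log units; within the scatter)), so it is the one compound of the four not set apart by the scatter from any other. No measurement at hand gives a reason for this result.

Since the 2-(4-methoxyphenyl)ethyl group differs from the benzyl groups in both its chain and its ring substituent, the compounds shown do not separate the contribution of each. They also leave open how 2-phenylethyl, a longer chain such as 3-phenylpropyl, or an amine on the ring would read here.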